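Urea to amide on the aryl pyrazole series

The compounds below may be only part of what the source reports. "The series", "measured", "known", "first", "only" and "open" are said of these compounds alone.

Measured so far in a functional assay on OVCAR-3 cells (Homo sapiens) for inhibition, read by sulforhodamine B assay, with a stated time of 48 h; a lower number here means a stronger inhibitor, a higher number a weaker inhibitor:
compound 1 `COc1cc(Cl)cc(-c2nn(-c3cccc(NC(=O)Nc4cccc(C(F)(F)F)c4)c3)cc2-c2ccncc2)c1` — 590 nM
compound 2 `COc1cc(Cl)cc(-c2nn(-c3cccc(NC(=O)Nc4ccc(Cl)c(C(F)(F)F)c4)c3)cc2-c2ccncc2)c1` — 450 nM

Compound 2 gives 450 nM in this assay, and the step of a 1.3-fold lower number from compound 1 to compound 2 (0.12 log units; within the scatter) leaves the two compounds within the scatter of each other. Compound 3 `COc1cc(Cl)cc(-c2nn(-c3cccc(NC(=O)c4cccc(C(F)(F)F)c4)c3)cc2-c2ccncc2)c1` differs from compound 2 at the carbonyl carbon: 3-(trifluoromethyl)phenyl in place of (4-chloro-3-(trifluoromethyl)phenyl)amino on a carbonyl carbon. Among the measured compounds shown here, no measured step touches a change of this kind; the only step known, from compound 1 to compound 2, concerns a chloro on the aromatic ring and was within the scatter. A weaker number is expected for compound 3, with a 3.3-fold higher number from compound 2 to compound 3 (0.52 log units; beyond the scatter) as the estimated step. Compound 3 is estimated at 1500 nM, within 400 nM to 6000 nM.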

Compound 3, half-maximal inhibitory concentration: 7690 nM
The estimate for compound 3 lay 5.1-fold (0.71 log units) below the measured number; the measured number lies above the stated range.
By their numbers in this assay, from the lowest: compounds 2 and 1 (each within the scatter of the next); then compound 3.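

In this assay, the carbonyl carbon proves far less tolerant than the aromatic chloro position: losing the amino nitrogen of the urea gives a 13-fold higher number from compound 1 to compound 3 (1.12 log units; beyond the scatter), and the change that also loses the chloro gives a 17-fold higher number from compound 2 to compound 3 (1.23 log units; beyond the scatter). Both steps lie beyond the scatter, so the (3-(trifluoromethyl)phenyl)amino link matters here in a way the chloro change did not show. No measured evidence accounts for this loss. Open, as far as these compounds go, is whether a methylene or an oxygen in place of that nitrogen would retain the urea-level numbers. Also open, from the compounds shown here alone, is how an amide carrying 4-chloro-3-(trifluoromethyl)phenyl would compare with compound 3.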